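The source may report more compounds than this note shows. Statements on the series, on what has been measured and on what is new or still open speak of the compounds shown alone.

For the measured compounds named here, compound 3, `CC(Sc1nc2c(cnn2C)c(=O)n1-c1ccccc1)c1ccncc1`, sits at the top of the three numbers measured so far: in an assay on isolated protein for inhibition of aldehyde dehydrogenase 1A1 (Homo sapiens) (a lower number here means a stronger inhibitor, a higher number a weaker inhibitor), compound 3 gives 451 nM. It stands level with compound 2, `COc1cccc(C(C)Sc2nc3c(cnn3C)c(=O)n2-c2ccccc2)c1`, which in this assay gives 451 nM; the step recorded as no change at the digits printed from compound 2 to compound 3 (within the scatter) is within the scatter. Compound 1, `CCC(Sc1nc2c(cnn2C)c(=O)n1-c1ccccc1)c1ccccc1`, gives 150 nM in this assay, and the step of a 3.0-fold higher number from compound 1 to compound 3 (0.48 log units; beyond the scatter) is the only one beyond the scatter among the three.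

Compound 4, `CC(Sc1nc2c(cnn2C)c(=O)n1-c1ccccc1)c1cccnc1`, differs from compound 3 only in the ring on the chain: pyridin-3-yl in place of pyridin-4-yl on a saturated chain carbon bound to a saturated chain carbon and a sulfur. Going by the values given here, the one measured step at this place, from compound 2 to compound 3, swapped a whole ring and left the number unchanged within the scatter; no measured step moves the ring nitrogen alone. Nothing in the data therefore calls for a shift, and compound 4 is expected to land close to compound 3, with the estimated step of a 1.0-fold lower number from compound 3 to compound 4 (0.00 log units; within the scatter) within the scatter. For compound 4 the estimate in this assay is 450 nM, within a range from 180 nM to 1100 nM.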

Compound 4, half-maximal inhibitory concentration: 139 nM
Beside the measured number, compound 4's estimate is 3.2-fold (0.51 log units) above it; measured number below the stated range.
By their numbers in this assay, from the lowest: compounds 4 and 1 (each within the scatter of the next); then compounds 2 and 3 (each within the scatter of the next).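

Moving only the ring nitrogen matters at this position: in this assay, pyridin-3-yl in place of pyridin-4-yl gives a 3.2-fold lower number from compound 3 to compound 4 (0.51 log units; beyond the scatter), so these two rings, alike in their counted atoms, are not interchangeable here. Pyridin-3-yl in place of 3-methoxyphenyl gives a 3.2-fold lower number from compound 2 to compound 4 (0.51 log units; beyond the scatter), whereas the pyridin-4-yl swap left the number unchanged at the digits printed, and 1-(pyridin-3-yl)ethyl in place of 1-phenylpropyl gives a 1.1-fold lower number from compound 1 to compound 4 (0.03 log units; within the scatter), which lies within the scatter. Nothing available accounts for the effect of the nitrogen's place.

From the compounds shown here alone, what pyridin-2-yl would give at this place remains open. So does whether 1-(pyridin-3-yl)propyl on the sulfur would take the number lower still, since the ring and the chain change together in the step from compound 1.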